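One methyl more: from compound 3 to compound 4

The source may report more compounds than this note shows. Statements on the series, on what has been measured and on what is new or still open speak of the compounds shown alone.

Compound 1, `CC(C)Nc1nc(O)c2cc(Cl)ccc2n1`, gives 78.7% in a functional assay on the whole organism (uterus) with Rattus norvegicus as the target, tested at 10 uM; a lower number here means a stronger effect, a higher number a weaker effect of the compound at the concentration tested.
Compound 2, `Oc1nc(NCC2CCCCC2)nc2ccc(Cl)cc12`, gives 86%.
Compound 3, `Oc1nc(NCc2ccccc2)nc2ccc(Cl)cc12`, gives 94.8%.

Compound 3 has the highest number of the three in this assay. Going by the values given here, the one single-point step known is a number 8.8 percentage points higher from compound 2 to compound 3 (within the scatter), so these two are not separable. Compound 1 sits further off, with a number that lies beyond the scatter from that of compound 3, though no single-point change links these two.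

Compound 4, `C[C@H](Nc1nc(O)c2cc(Cl)ccc2n1)c1ccccc1`, differs from compound 3 by methyl in place of hydrogen on a saturated chain carbon bound to an aromatic carbon and a nitrogen on an aromatic ring.

Among the compounds with values here, no measured step bears on this change: the one step known, from cyclohexyl to phenyl, concerns a different part of the chain and was within the scatter. There is therefore no ground to expect a move beyond the scatter in this assay, and the step from compound 3 to compound 4 is estimated at a number 4.8 percentage points lower from compound 3 to compound 4 (within the scatter).

Compound 4 is expected to give 90% in this assay, within the range 74% to 102%.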

Compound 4, a percentage reported as activity, at one concentration (the size of the read-out at that concentration, not a potency): 92.4%
Compound 4: the middle estimate sits 2.4 percentage points below what was measured, and the stated range covers the measured number.
By their numbers in this assay, from the lowest: compounds 1, 2, 4 and 3 (each within the scatter of the next, the first and the last beyond it).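

In this assay the step is a number 2.4 percentage points lower from compound 3 to compound 4 (within the scatter), so at this saturated chain carbon bound to an aromatic carbon and a nitrogen on an aromatic ring, methyl in place of hydrogen leaves the read-out not separable from that of the parent. This is the only change shown at this carbon, and it adds one carbon without a measurable shift at the concentration tested. Nothing measured here speaks to the origin of this result.

The compounds shown leave open whether a larger group at this carbon, such as ethyl or a longer chain, or a group of another kind, such as hydroxymethyl or an amine, would also stay within the scatter. They also leave open how the opposite configuration at this carbon would read.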